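Swapping a Trifluoromethyl for a Methylcarbamoyl

This account rests on a few compounds, and the source may have more. Where it says the series, first, only, none or still open, it means among the compounds named here.

Of the compounds shown here, two built on the same core have so far been tested in a functional assay on the whole organism for inhibition, with Rattus norvegicus as the target; on this read-out higher numbers stand for an effect only at larger amounts of compound and lower numbers for an effect already at smaller amounts. Compound 1 `CC1CC/C(=N\Nc2cccc(Br)c2)c2ncc(C(=O)O)c(=O)n21` gives 0.4 umol/kg in this assay. Compound 2 `CC1CC/C(=N\Nc2ccc(C(F)(F)F)cc2)c2ncc(C(=O)O)c(=O)n21` gives 38.6 umol/kg, the higher of the two numbers, and the gap to compound 1 lies well beyond the scatter, so compound 2 needs much more material for the same effect.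

Compound 3 `CNC(=O)c1ccc(N/N=C2\CCC(C)n3c2ncc(C(=O)O)c3=O)cc1` has not been measured. It differs from compound 2 in one place: methylcarbamoyl in place of trifluoromethyl on an aromatic carbon. Among the compounds with values here, no measured pair shows this kind of change, so there is no direct guide to its size or direction. Compound 3 is expected to move toward lower numbers, with an estimated step of a 3.2-fold lower number from compound 2 to compound 3 (0.51 log units; beyond the scatter), modest enough that it might not clear the scatter. The estimate for compound 3 is 12 umol/kg, with a likely range from 2 umol/kg to 60 umol/kg.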

Compound 3, dose for 50% inhibition: 9.6 umol/kg
Estimate against measurement, compound 3: 1.3-fold (0.10 log units) above; low and high end bracket the measured number.
By their numbers in this assay, from the lowest: compound 1; then compound 3; then compound 2.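

In this assay, methylcarbamoyl in place of trifluoromethyl on this aromatic carbon, para to a large group, gives a 4.0-fold lower number from compound 2 to compound 3 (0.60 log units; beyond the scatter). Within the data shown here, this is the first single-change step at this position, and it shows that the number responds to the group placed here. The two groups have the same count of heavy atoms, but methylcarbamoyl brings a hydrogen-bond donor and a hydrogen-bond acceptor where trifluoromethyl has neither, and no measurement shown ties the shift to any feature of either group.

A single step cannot separate the part played by the amide hydrogen from that of the carbonyl. Going by these compounds, how a nitrile, an amine or a longer amide chain on the same carbon would read out remains open.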